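A few compounds are considered here, and "the series" means these few. Any claim that something is new, unique, unknown or untested is made for them only; others in the source may bear on it.

Measured so far in a functional assay on cells (Melanoma cell) for cytotoxicity against Melanoma cell line (Homo sapiens), read by sulforhodamine B assay, with a stated time of 48 h; a lower number here means that less compound is tolerated, a higher number that more compound is tolerated:
- compound 1 `COc1nc2sc(C)cn2c1C=C1C(=O)N(C)c2ccccc21`: 93400 nM
- compound 2 `O=C1Nc2ccccc2C1=Cc1c(-c2ccncc2)nc2sccn12`: 92300 nM
- compound 3 `COc1nc2sc(C)cn2c1/C=C1/C(=O)Nc2ccc(O)cc21`: 94000 nM

In this assay, compound 3 gives 94000 nM. That places it level with the other two compounds, since the gaps to both lie within the usual scatter of repeated measurements. On these data, the three cannot be ranked.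

The next compound, compound 4 `COc1nc2sc(C)cn2c1/C=C1/C(=O)Nc2ccccc21`, differs from compound 3 in one place: hydrogen in place of hydroxy on an aromatic carbon. In words, hydrogen takes the place of hydroxy on an aromatic carbon.

Among the compounds with values here, no two measured compounds differ in only one place, so no measured step shows directly what this swap does. Within the data shown here, the only guide is the overall picture. Compound 1 at 93400 nM and compound 2 at 92300 nM differ from compound 3 in more than one place, yet their values stay within the scatter of its value. With so little to go on, no shift beyond the scatter is expected in either direction.

The expected change, a 1.0-fold lower number from compound 3 to compound 4 (0.00 log units; within the scatter), is estimated to stay within the scatter. The estimate for compound 4 is 93000 nM, with an expected range of 72000 nM to 100000 nM.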

Compound 4, concentration lethal to 50% of the cells: 94900 nM
Estimate against measurement, compound 4: 1.0-fold (0.01 log units) below; the range from low to high includes it.
By their numbers in this assay, from the lowest: compounds 2, 1, 3 and 4 (each within the scatter of the next).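

In this assay, within the data shown here, putting hydrogen in place of hydroxy on this aromatic carbon gives a 1.0-fold higher number from compound 3 to compound 4 (0.00 log units; within the scatter) and so provides the first direct comparison between two compounds that differ in only one place. The earlier values could only suggest that the compounds sat close together. Those compounds differ in more than one place, whereas this pair isolates a single group and shows that, in this one setting, the hydroxy with its hydrogen-bond donor and acceptor makes no difference that can be told from the scatter. No accompanying measurement offers an explanation for why the two compounds read alike.

Among these compounds, whether an amine, a carboxylic acid or a fluorine on this same aromatic carbon would give a number beyond the scatter remains open, since hydrogen and hydroxy are the only two groups compared here. Also open, going by these compounds, is whether the same swap would read alike on the core of compound 2, because this single pair speaks only for the core it shares in this assay and for no other cell line.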